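Swapping Chloro for Fluoro: Tolerance on Vero Cells

This account rests on a few compounds, and the source may have more. Where it says the series, first, only, none or still open, it means among the compounds named here.

In a toxicity assay on Vero cells (Chlorocebus sabaeus) for cytotoxicity (a lower number here means that less compound is tolerated, a higher number that more compound is tolerated), compound 1 `COc1ncc(-c2ccccc2)cc1[C@@H](c1ccccc1)[C@@](O)(CCN(C)C)c1ccccc1` gives > 50 ug/mL, which is a limit of the assay rather than a number. Compound 2 `COc1nc(-c2ccc(Cl)cc2)ccc1[C@@H](c1ccccc1)[C@@](O)(CCN(C)C)c1cccc2ccccc12` likewise gives > 50 ug/mL in this assay, again only a limit. Compound 3 `COc1nc(-c2ccccc2F)ccc1[C@@H](c1ccccc1)[C@@](O)(CCN(C)C)c1cccc2ccccc12` gives > 50 ug/mL, also a limit. Compound 2 thus stands at the limit of > 50 ug/mL in this assay, at which 3 of the 3 values shown sit, with no number to place it more finely. Among the compounds with values here, the one measured step that resembles the change here is a step that the two limits leave unreadable from compound 2 to compound 3, and its size cannot be read. Compound 4 `COc1nc(-c2ccc(F)cc2)ccc1[C@@H](c1ccccc1)[C@@](O)(CCN(C)C)c1cccc2ccccc12` differs from compound 2 by fluoro in place of chloro on an aromatic carbon. With every value shown sitting at the limit, no step beyond the scatter is expected, so compound 4 is expected to sit near 60 ug/mL, within 35 ug/mL to 150 ug/mL. That amounts to an expected step that the limit leaves unreadable from compound 2 to compound 4.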

Compound 4, half-maximal cytotoxic concentration: > 50 ug/mL
Compound 4: no number, only a limit; the forecaster's own chance of this, stated with the estimate: 85%; the middle value lies beyond the limit too.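

Compound 4 also gives only a limit, so the steps linking it to compound 2 and compound 3 cannot be read: the limit of > 50 ug/mL in this assay, at which 4 of the 4 values shown sit. On these data alone, how far compound 2 and compound 4 truly differ in this assay stays open.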